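The compounds below may be only part of what the source reports. "The series", "measured", "known", "first", "only" and "open" are said of these compounds alone.

In a functional assay on A-375 cells (Homo sapiens) for antiproliferative activity, read by CCK-8 assay, with a stated time of 72 h, tested at 2 uM (on this read-out higher numbers stand for a stronger effect at the one concentration tested and lower numbers for a weaker effect), compound 3 `CN1CCN(C(=S)SCc2ccc(C(=O)Nc3ccccc3N)cc2)CC1` gives 36.6%, the second highest of the three numbers shown. Compound 2 `CC1CCCCN1C(=S)SCc1ccc(C(=O)Nc2ccccc2N)cc1` gives 42.5%, and the step of a number 5.9 percentage points lower from compound 2 to compound 3 (within the scatter) stays within the scatter. Compound 1 `Nc1ccccc1NC(=O)c1ccc(CSC(=S)N2CCc3ccccc32)cc1` gives 25.7%, and the step of a number 10.9 percentage points higher from compound 1 to compound 3 (beyond the scatter) lies beyond it. Compound 4 `CN(Cc1cccnc1)C(=S)SCc1ccc(C(=O)Nc2ccccc2N)cc1` differs from compound 3 in one place: methyl((pyridin-3-yl)methyl)amino in place of 4-methylpiperazin-1-yl on a thiocarbonyl carbon. The measured steps that exchange the group on the thiocarbonyl carbon are a number 16.8 percentage points higher from compound 1 to compound 2 (beyond the scatter), a number 10.9 percentage points higher from compound 1 to compound 3 (beyond the scatter) and a number 5.9 percentage points lower from compound 2 to compound 3 (within the scatter), all modest at most, and nothing measured puts methyl((pyridin-3-yl)methyl)amino in that place. A step of a number 1.6 percentage points lower from compound 3 to compound 4 (within the scatter) is therefore expected, not clearly beyond the scatter in either direction. For compound 4 the estimate is 35%, with a range from 20% to 50%.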

Compound 4, a percentage reported as inhibition, at one concentration (the size of the read-out at that concentration, not a potency): 39.4%
Beside the measured number, compound 4's estimate is 4.4 percentage points below it; the measured number falls inside the stated range.
By their numbers in this assay, from the lowest: compound 1; then compounds 3, 4 and 2 (each within the scatter of the next).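

In this assay, methyl((pyridin-3-yl)methyl)amino on the thiocarbonyl carbon performs like the two non-aromatic ring groups: a number 2.8 percentage points higher from compound 3 to compound 4 (within the scatter) and a number 3.1 percentage points lower from compound 2 to compound 4 (within the scatter). Its six-membered aromatic ring does not bring the number down to that of 2,3-dihydro-1H-indol-1-yl, with a number 13.7 percentage points higher from compound 1 to compound 4 (beyond the scatter), so an aromatic ring in this group does not by itself go with the lowest number. No supporting data explain these differences. Open, on these data alone, is whether morpholin-4-yl or diethylamino in this place would give a similar number.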